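Series notes: proline nitrile amides, step from compound 1 to compound 4

The source may report more compounds than this note shows. Statements on the series, on what has been measured and on what is new or still open speak of the compounds shown alone.

Measured so far:
compound 1 `CCCNC(=O)[C@@H]1CN[C@H](C(=O)N2CCC[C@H]2C#N)C1` — 21%
compound 2 `CCN(C)C(=O)[C@H]1C[C@@H](C(=O)N2CCC[C@H]2C#N)N[C@H]1C` — 79%
compound 3 `C[C@@H]1N[C@H](C(=O)N2CCC[C@H]2C#N)C[C@@H]1C(=O)N1CCOCC1` — 85%

In an assay on the whole organism (plasma, strain Sprague-Dawley) for inhibition of Dipeptidyl peptidase 4 (Rattus norvegicus), with a stated time of 10 h, at a dose of 1 mg/kg by the oral route (a higher number here means more inhibition at the dose given (going by the name of the read-out), a lower number less inhibition), compound 1 gives the lowest of the three numbers, well beyond the scatter below compound 2 and compound 3. Compound 4 `CCN(C)C(=O)[C@@H]1CN[C@H](C(=O)N2CCC[C@H]2C#N)C1` differs from compound 1 by ethyl(methyl)amino in place of propylamino on a carbonyl carbon. Among the measured compounds shown here, the only measured step at that carbonyl carbon is a number 6 percentage points higher from compound 2 to compound 3 (within the scatter), which exchanges one tertiary amine for another and says nothing about a secondary amine giving way to a tertiary one. Compounds 2 and 3 also carry a methyl on the core that compound 1 lacks, so their gap to compound 1 cannot be split between the two changes. A rise is plausible but unsupported by any single step, so compound 4 is estimated at 50% (range 20% to 80%), an expected a number 29 percentage points higher from compound 1 to compound 4 (beyond the scatter).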

Compound 4, a percentage reported as inhibition, in the whole organism at one dose (the size of the read-out at that dose, not a potency): 34%
Compound 4: the middle estimate sits 16 percentage points above what was measured; the measured number falls inside the stated range.
By their numbers in this assay, from the lowest: compound 1; then compound 4; then compounds 2 and 3 (each within the scatter of the next).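

In this assay, among the compounds shown here, ethyl(methyl)amino in place of propylamino on a carbonyl carbon gives a number 13 percentage points higher from compound 1 to compound 4 (beyond the scatter), a first reading of this change and a modest one. Hydrogen in place of methyl on a saturated ring carbon gives a number 45 percentage points lower from compound 2 to compound 4 (beyond the scatter), so that methyl carries far more of the read-out than the change on the carbonyl carbon does. No measurement at hand bears on the origin of either step.

Open, as far as these compounds go, is how an ethyl group or a fluorine atom at that ring carbon would read in this assay. Also open, from the compounds shown here alone, is whether morpholin-4-yl on the carbonyl carbon holds its number on the core of compound 4.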